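Trimming the carbamate end of a receptor inhibitor series

This account rests on a few compounds, and the source may have more. Where it says the series, first, only, none or still open, it means among the compounds named here.

In a functional assay on isolated protein for inhibition of Glucose-dependent insulinotropic receptor (Homo sapiens), read by HTRF and cAMP accumulation (on this read-out higher numbers stand for an effect only at larger amounts of compound and lower numbers for an effect already at smaller amounts), two compounds have been measured so far. Compound 1 `Cc1nc(S(C)(=O)=O)ccc1Oc1ncnc(OC2CCN(C(=O)OC(C)(C)C#N)CC2)c1F` gives 92.9 nM, and compound 2 `Cc1nc(S(C)(=O)=O)ccc1Oc1ncnc(OC2CCN(C(=O)OC3(C(F)(F)F)CCC3)CC2)c1F` gives 14.3 nM. Within the data shown here, the single step between them, a 6.5-fold lower number from compound 1 to compound 2 (0.81 log units; beyond the scatter), leaves compound 2 with the lower of the two numbers and compound 1 as its only neighbour. Compound 3 `Cc1nc(S(C)(=O)=O)ccc1Oc1ncnc(OC2CCN(C(=O)C(C)(C)F)CC2)c1F` is the next member; it differs from compound 2 by a group of 4 heavy atoms (3 carbon, 1 fluorine; no ring) in place of a group of 9 heavy atoms (5 carbon, 1 oxygen, 3 fluorine; one four-membered non-aromatic ring of carbon only), on a carbonyl carbon. Among the measured compounds shown here, no measured step covers this exact exchange, so the only guide is the earlier step, which showed that changing the group on the carbonyl carbon can shift the number by a modest amount. Because the earlier exchange at this position gave a 6.5-fold lower number from compound 1 to compound 2 (0.81 log units; beyond the scatter), a drift back toward the number of compound 1 seems plausible, though the new group is smaller than either earlier one. Compound 3 is therefore expected to show a 4.2-fold higher number from compound 2 to compound 3 (0.62 log units; beyond the scatter). The estimate for compound 3 is 60 nM, with a range from 20 nM to 200 nM.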

Compound 3, half-maximal effective concentration: 76.3 nM
Compound 3: the middle estimate sits 1.3-fold (0.10 log units) below what was measured; the range from low to high includes it.
By their numbers in this assay, from the lowest: compound 2; then compounds 3 and 1 (each within the scatter of the next).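

In this assay, putting 1-fluoro-1-methylethyl on the carbonyl carbon gives a 5.3-fold higher number from compound 2 to compound 3 (0.73 log units; beyond the scatter), so the low number of compound 2 does not survive this exchange. Set against the 1-cyano-1-methylethoxy group, the same new group gives a 1.2-fold lower number from compound 1 to compound 3 (0.09 log units; within the scatter), which is within the scatter, so compound 1 and compound 3 cannot be told apart even though only compound 1 has an oxygen on the carbonyl carbon. Among these three compounds, only compound 2, the one with a four-membered ring in this group, stands apart from the others.

As far as these compounds go, it remains open whether that ring or the trifluoromethyl group goes with the low number, which a plain 1-methylcyclobutyl group on the same oxygen could help to separate. The compounds shown come with no measurement that explains the differences among these groups.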